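The compounds below may be only part of what the source reports. "The series", "measured", "known", "first", "only" and "open" are said of these compounds alone.

Of the compounds shown here, three share one core and have been tested in a functional assay for inhibition, tested at 40 ug/mL; on this read-out lower numbers stand for a weaker effect and higher numbers for a stronger effect at the one concentration tested. Compound 1 `COc1ccc(-c2cc(-c3cc(C(C)C)c(O)cc3C)[nH]c(=O)c2C#N)c(OC)c1` gives 37.5% in this assay, compound 2 `COc1ccc(-c2cc(-c3cc(C(C)C)c(O)cc3C)[nH]c(=O)c2C#N)cc1OC` gives 44%, and compound 3 `COc1cccc(-c2cc(-c3cc(C(C)C)c(O)cc3C)[nH]c(=O)c2C#N)c1` gives 30%. Compound 3 holds the smallest of the three numbers, although a number 7.5 percentage points lower from compound 1 to compound 3 (within the scatter) and only a number 14 percentage points lower from compound 2 to compound 3 (beyond the scatter). Compound 4 `Cc1cc(O)c(C(C)C)cc1-c1cc(-c2ccccc2)c(C#N)c(=O)[nH]1` is not yet measured; it differs from compound 3 by hydrogen in place of methoxy on an aromatic carbon. Within the data shown here, one measured step bears on this change, since it too is hydrogen in place of methoxy on an aromatic carbon: a number 14 percentage points lower from compound 2 to compound 3 (beyond the scatter). A drop of similar, modest size is therefore expected in this assay, with the scatter leaving room for no change at all. Compound 4 is estimated at 20%, between 8% and 32%. This estimate means an expected a number 10 percentage points lower from compound 3 to compound 4 (within the scatter).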

Compound 4, a percentage reported as inhibition, at one concentration (the size of the read-out at that concentration, not a potency): 29%
Compound 4: the middle estimate sits 9 percentage points below what was measured; low and high end bracket the measured number.
By their numbers in this assay, from the lowest: compounds 4, 3, 1 and 2 (each within the scatter of the next, the first and the last beyond it).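

In this assay hydrogen in place of methoxy no longer costs anything measurable once a single methoxy is left: a number 1 percentage points lower from compound 3 to compound 4 (within the scatter) stays within the scatter, unlike a number 14 percentage points lower from compound 2 to compound 3 (beyond the scatter) for the same exchange. Among these compounds, the plain phenyl thus remains level with the 2,4-dimethoxyphenyl, as a number 8.5 percentage points lower from compound 1 to compound 4 (within the scatter) shows, and only the 3,4-dimethoxyphenyl stands apart, with a number 15 percentage points lower from compound 2 to compound 4 (beyond the scatter) as the one step to compound 4 beyond the scatter. No measurement shown explains this difference between the two exchanges. On these data alone, whether an amine, a hydroxy group or a carboxylic acid on this aromatic carbon would move the number remains open.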